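The source may hold more compounds than are shown below. What is called first, only, known or untested is meant among the compounds shown, and "the series" means these compounds.

Compound 1 `CC(C)(C)OC[C@@H](O)C(=O)N1[C@H](C(=O)NCc2cc(Cl)ccc2-n2cnnn2)C[C@@H]2C[C@@H]21`: 4.5 10^-6 cm/s
Compound 2 `COC(C)(C)[C@@H](O)C(=O)N1C[C@H]2C[C@H]2[C@H]1C(=O)NCc1cc(Cl)ccc1-n1cnnn1`: 3.5 10^-6 cm/s
Compound 3 `CC(C)(C)[C@@H](O)C(=O)N1CC(=O)C[C@H]1C(=O)NCc1cc(Cl)ccc1-n1cnnn1`: 0.8 10^-6 cm/s

These numbers come from an ADME assay on Caco-2 cells (Homo sapiens) for permeability, read by LC-MS, in the apical to basolateral direction, with a stated time of 60 min, at pH 6.5; a higher number here means that the compound crosses the layer faster, a lower number that the compound crosses the layer more slowly. Compound 1 (4.5 10^-6 cm/s) and compound 2 (3.5 10^-6 cm/s) lie within the scatter of each other, and compound 3 (0.8 10^-6 cm/s) falls beyond the scatter from compound 1.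

Compound 4 `CC(C)(C)[C@@H](O)C(=O)N1[C@H](C(=O)NCc2cc(Cl)ccc2-n2cnnn2)C[C@@H]2C[C@@H]21` is not yet measured. It differs from compound 1 as follows: tert-butyl in place of (tert-butoxy)methyl on a saturated chain carbon bound to a carbonyl carbon and an oxygen on a saturated carbon with tert-butyl in place of (tert-butoxy)methyl on a saturated chain carbon bound to a carbonyl carbon and an oxygen on a saturated carbon.

Among the compounds with values here, no measured pair isolates this change. Compound 3 carries the tert-butyl too, but its core also differs, so its value (0.8 10^-6 cm/s) cannot be read for this change alone. In this assay a small upward move is expected, with nothing beyond the scatter. The expected step of a 1.3-fold higher number from compound 1 to compound 4 (0.12 log units; within the scatter) stays within the scatter. For compound 4 the estimated value is 6 10^-6 cm/s with an expected range from 3 10^-6 cm/s to 12 10^-6 cm/s in this assay.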

Compound 4, apparent permeability: 16 10^-6 cm/s
Beside the measured number, compound 4's estimate is 2.7-fold (0.43 log units) below it; the measured number lies above the stated range.
By their numbers in this assay, from the lowest: compound 3; then compounds 2 and 1 (each within the scatter of the next); then compound 4.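

Within the data shown here, on the saturated chain carbon bound to a carbonyl carbon and an oxygen on a saturated carbon, the shared core held constant, tert-butyl in place of (tert-butoxy)methyl gives a step beyond the scatter in this assay (a 3.6-fold higher number from compound 1 to compound 4 (0.55 log units; beyond the scatter)), the only step that isolates one place. The group that leaves has 6 heavy atoms and 1 hydrogen-bond acceptor, the group that enters 4 heavy atoms and 0 hydrogen-bond acceptors, and this single pair cannot separate these two differences. No measurement at hand bears on what lies behind the step.

On these data alone, whether the step carries over to another core remains open. So does the outcome at this position with isopropyl, a primary amine or a carboxylic acid in place of tert-butyl.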